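A Dimethoxyphenyl in Place of a Dichlorophenyl

The source may hold more compounds than are shown below. What is called first, only, known or untested is meant among the compounds shown, and "the series" means these compounds.

Measured so far in a functional assay on NCI/ADR-RES cells (Homo sapiens) for inhibition, read by sulforhodamine B assay, with a stated time of 48 h; a lower number here means that less compound is tolerated, a higher number that more compound is tolerated:
Compound 1 `COc1cc(-c2cc(/C=C/C(=O)c3ccc(Cl)c(Cl)c3)[nH]n2)cc(OC)c1OC` gives > 100000 nM, which is a limit of the assay rather than a number.
Compound 2 `COc1ccc(-c2cc(/C=C/C(=O)c3cc(OC)c(OC)c(OC)c3)[nH]n2)cc1OC` gives > 100000 nM, also a limit.
Compound 3 `COc1ccc(-c2cc(/C=C/C(=O)c3ccc(N)cc3)[nH]n2)cc1` gives > 100000 nM, again a limit.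

Compound 1 therefore stands at the edge of what this assay reports, with no number of its own, because of the limit of > 100000 nM in this assay, at which 3 of the 3 values shown sit. Compound 4 `COc1ccc(C(=O)/C=C/c2cc(-c3cc(OC)c(OC)c(OC)c3)n[nH]2)cc1OC` differs from compound 1 in a single place: 3,4-dimethoxyphenyl in place of 3,4-dichlorophenyl on a carbonyl carbon. Going by the values given here, no step between two measured compounds is available to gauge how much such a change on the carbonyl carbon can move the read-out. What can be said is that compound 1, compound 2 and compound 3 carry different aryl groups on the carbonyl carbon, and every one of them sits at the limit. On that basis the change from compound 1 to compound 4 is expected to produce no step beyond the scatter, as a number no higher from compound 1 to compound 4 (the limit leaves the size open) expresses. Compound 4 is accordingly expected to give about 100000 nM, within a range of 40000 nM to 250000 nM, most probably as another limit.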

Compound 4, concentration lethal to 50% of the cells: > 100000 nM
Compound 4: only a limit was reported (the forecaster's own chance of this, stated with the estimate: 85%); the middle value sits exactly at the limit.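

No step can be read between compound 1 and compound 4, because both give only a limit rather than a number: the limit of > 100000 nM in this assay, at which 4 of the 4 values shown sit.

The compounds shown leave open how far each lies beyond that limit, and whether changing the aryl group on the carbonyl carbon moves the read-out at all.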